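Swapping the oxazole for a methylpyrazole in an inert series

A few compounds are considered here, and "the series" means these few. Any claim that something is new, unique, unknown or untested is made for them only; others in the source may bear on it.

Compound 3, with structure `c1cc(-c2ncco2)c2c(c1)C(c1ncc[nH]1)CC2`, carries a 1,3-oxazol-2-yl group on the shared core. In a functional assay on CHO cells for agonist activity at Alpha-1B adrenergic receptor (Homo sapiens), read by FLIPR and calcium flux (a higher number here means that more compound is needed for the effect, a lower number that less compound is needed), compound 3 gives only a limit, > 10000 nM. Compound 1, with structure `Cn1ccc(-c2cccc3c2CCC3c2ncc[nH]2)n1`, also gives only a limit in this assay, > 10000 nM. Compound 2, with structure `c1cncc(-c2cccc3c2CCC3c2ncc[nH]2)c1`, likewise gives only a limit in this assay, > 10000 nM. All three values sit at the limit of > 10000 nM in this assay, at which 3 of the 3 values shown sit, so the step that the two limits leave unreadable from compound 1 to compound 2, the step that the two limits leave unreadable from compound 1 to compound 3 and the step that the two limits leave unreadable from compound 2 to compound 3 are all unreadable.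

Compound 4, with structure `Cn1nccc1-c1cccc2c1CCC2c1ncc[nH]1`, differs from compound 3 as follows: 1-methyl-1H-pyrazol-5-yl in place of 1,3-oxazol-2-yl on an aromatic carbon. Among the measured compounds shown here, no measured step in this assay resolves a direction for such a change, and the aromatic groups tried so far, including the 1-methyl-1H-pyrazol-3-yl of compound 1, all leave the response at the limit. Compound 4 is therefore expected to remain near that limit, with a step that the limit leaves unreadable from compound 3 to compound 4 in this assay. The estimate for compound 4 in this assay is 15000 nM, within a range of 3000 nM to 60000 nM.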

Compound 4, half-maximal effective concentration: > 10000 nM
Compound 4: a limit, no number; the forecaster's own chance of this, stated with the estimate: 75%; the middle value does not contradict the limit.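

In this assay compound 4 gives only a limit, > 10000 nM, so its steps from compound 1, compound 2 and compound 3 cannot be read. The compounds shown leave open whether any group at this place on the shared core gives a measurable response in this assay.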